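Swapping trifluoromethoxy for cyano on a weak sulfonamide

The source may report more compounds than this note shows. Statements on the series, on what has been measured and on what is new or still open speak of the compounds shown alone.

Compound 3 `CCN(CC)c1ccc2cc(C(=O)c3ccc(N4CCN(C(=O)CN5CCN(S(=O)(=O)c6ccc(OC(F)(F)F)cc6)CC5)CC4)cc3)oc2c1` carries a sulfonyl-linked aryl group on the shared core. In a functional assay on A549 cells (Homo sapiens) for cytotoxicity, read by MTT assay, with a stated time of 48 h (on this read-out higher numbers stand for weaker inhibition and lower numbers for stronger inhibition), compound 3 gives only a limit, > 40000 nM, sitting at the limit of > 40000 nM in this assay, at which 1 of the 3 values shown sits. Among the compounds with values here, for comparison, compound 1 `CCN(CC)c1ccc2cc(C(=O)c3ccc(N4CCN(C(=O)CN5CCN(C(=O)CCl)CC5)CC4)cc3)oc2c1` gives 3060 nM and compound 2 `CCN(CC)c1ccc2cc(C(=O)c3ccc(N4CCN(C(=O)CN5CCN(C(=O)/C=C/c6ccccc6)CC5)CC4)cc3)oc2c1` gives 9450 nM; the one measured single-point step, a 3.1-fold higher number from compound 1 to compound 2 (0.49 log units; beyond the scatter), concerns the group on the carbonyl carbon, not the aryl ring. Compound 4 `CCN(CC)c1ccc2cc(C(=O)c3ccc(N4CCN(C(=O)CN5CCN(S(=O)(=O)c6ccc(C#N)cc6)CC5)CC4)cc3)oc2c1` differs from compound 3 by cyano in place of trifluoromethoxy on an aromatic carbon. Within the data shown here, no measured step covers this change. Because compound 3 sits at the limit > 40000 nM, little anchors the step. Compound 4 is expected to stay weak, with an estimated step of a number no higher from compound 3 to compound 4 (the limit leaves the size open). Compound 4 is therefore estimated at 40000 nM, between 10000 nM and 120000 nM.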

Compound 4, half-maximal inhibitory concentration: > 40000 nM
Compound 4: no number, only a limit; the forecaster's own chance of this, stated with the estimate: 60%; the middle value sits exactly at the limit.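

Putting (4-cyanophenyl)sulfonyl on the ring nitrogen in place of the carbonyl-linked groups gives an at least 4.2-fold higher number from compound 2 to compound 4 (0.62 log units; beyond the scatter) and an at least 13-fold higher number from compound 1 to compound 4 (1.11 log units; beyond the scatter). The step from compound 3 to compound 4 cannot be read, and cyano and trifluoromethoxy cannot be ranked against each other. In this assay, a second sulfonyl-linked aryl compound now sits at the limit: the limit of > 40000 nM in this assay, at which 2 of the 4 values shown sit.

From the compounds shown here alone, it remains open whether an amine or a carboxylic acid on that aromatic carbon would give a number rather than a limit. A methyl sulfonyl group, with no aryl ring, is equally untested among the compounds shown.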